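This account rests on a few compounds, and the source may have more. Where it says the series, first, only, none or still open, it means among the compounds named here.

- Compound 1 (`CN(CCN)C(=O)c1cc(-c2ccccc2)sc1NC(N)=O`) reads ("not determined" (no result reported))
- Compound 2 (`CS(=O)(=O)c1ccc(-c2cc(C(=O)N[C@H]3CCCNC3)c(NC(N)=O)s2)cc1`) reads (200 nM)

In a functional assay on HT-29 cells (Homo sapiens) (on this read-out lower numbers stand for an effect already at smaller amounts and higher numbers for an effect only at larger amounts of compound), compound 1 has no number ("not determined" (no result reported)), so it offers no value to start from. Compound 3 (`NCCNC(=O)c1cc(-c2ccccc2)sc1NC(N)=O`) differs from compound 1 by one change (hydrogen in place of methyl on an amide-type nitrogen), hydrogen in place of methyl on an amide-type nitrogen. Among the measured compounds shown here, no measured step shows what this change does, so a shift within the usual scatter, in no set direction, is expected. For the measured compounds named here, compound 2 (200 nM) is the only number available, and it differs from compound 3 in more than this one place, which makes it a loose guide. For compound 3 the expected value is 1500 nM, with an estimated range from 300 nM to 8000 nM.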

Compound 3, half-maximal effective concentration: 960 nM
Estimate against measurement, compound 3: 1.6-fold (0.19 log units) above; measured number inside the range.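

No step can be read from compound 1 to compound 3 in this assay: compound 1 gives "not determined" (no result reported). As far as these compounds go, what hydrogen in place of methyl on the amide-type nitrogen does to this read-out stays open. No supporting evidence bears on this result.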